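The source may report more compounds than this note shows. Statements on the series, on what has been measured and on what is new or still open speak of the compounds shown alone.

Of the compounds shown here, three built on a shared core have been tested in a functional assay on OVCAR-3 cells (Homo sapiens) for inhibition, read by sulforhodamine B assay, with a stated time of 48 h; a higher number here means a weaker inhibitor of growth, a lower number a stronger inhibitor of growth. Compound 1 `CCOC(=O)C1=C(C)NC(=S)NC1c1ccc(O)c(O)c1` gives 25 ug/mL. Compound 2 `CCOC(=O)C1=C(C)NC(=S)NC1c1ccc(OC)cc1` gives 0.99 ug/mL. Compound 3 `CCOC(=O)C1=C(C)NC(=O)NC1c1ccc(SC)cc1` gives 10 ug/mL. Of these three numbers, compound 2 stands lowest, so it is the strongest growth inhibitor of the set; the nearest neighbour is compound 3, whose number is higher by a margin beyond the usual scatter, and compound 1 lies furthest away, again beyond the scatter.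

The next compound, compound 4 `CCCc1ccc(C2NC(=S)NC(C)=C2C(=O)OCC)cc1`, is not yet measured. It differs from compound 2 in a single place: propyl in place of methoxy on an aromatic carbon. Among the measured compounds shown here, no pair of measured compounds differs in only this one place, so the data give no direct guide to what such a swap does; compound 3 differs from compound 2 in more than one place and cannot serve as a guide either.

For this reason the expected step in this assay from compound 2 to compound 4 is modest, a 2.0-fold higher number from compound 2 to compound 4 (0.31 log units; beyond the scatter), leaning slightly toward a higher number but not clearly beyond the scatter. Compound 4 is therefore estimated at 2 ug/mL, with a range from 0.7 ug/mL to 6 ug/mL.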

Compound 4, concentration for 50% growth inhibition: 38.1 ug/mL
Estimate against measurement, compound 4: 19-fold (1.28 log units) below; measured number outside the range, above it.
By their numbers in this assay, from the lowest: compound 2; then compound 3; then compounds 1 and 4 (each within the scatter of the next).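

In this assay, among the compounds shown here, the swap of propyl in place of methoxy on an aromatic carbon, para to a large group, is a large step, a 38-fold higher number from compound 2 to compound 4 (1.59 log units; beyond the scatter) and it is the first direct reading of any change at this place. It shows that this position does not treat these two small groups alike: growth inhibition depends strongly on which of them sits there, at least on the core of compound 2. The two groups differ in what they bring, methoxy an oxygen and a hydrogen-bond acceptor, propyl only carbon and no acceptor, but nothing shown gives a cause for the loss of growth inhibition.

On these data alone, with a single pair, it remains open whether the oxygen or the chain length matters more: an ethoxy group would keep the oxygen in a longer chain, while an ethyl chain would keep only carbon in a shorter one. As far as these compounds go, it is also open whether the position would take a quite different group, such as an amine or a carboxylic acid, and whether the same swap would give a step of similar size on the core of compound 3.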